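The source may hold more compounds than are shown below. What is called first, only, known or untested is meant among the compounds shown, and "the series" means these compounds.

Measured in a functional assay on HL-60 cells (Homo sapiens) for antiproliferative activity, read by XTT assay, with a stated time of 72 h; a higher number here means a weaker inhibitor, a lower number a stronger inhibitor:

Compound 1 `COc1ncnc2c1c(-c1ccsc1)cn2[C@@H]1O[C@H](CO)[C@@H](O)[C@H]1O`: 130 nM
Compound 2 `CN(C)c1ncnc2c1c(-c1ccsc1)cn2[C@@H]1O[C@H](CO)[C@@H](O)[C@H]1O`: 1920 nM
Compound 3 `COc1nc(N)nc2c1c(-c1ccsc1)cn2[C@@H]1O[C@H](CO)[C@@H](O)[C@H]1O`: only a limit of the assay, > 20000 nM

Compound 1 stands at the lowest of the two numbers shown. Compound 2 sits well above it, by a 15-fold higher number from compound 1 to compound 2 (1.17 log units; beyond the scatter). Compound 3 gives no number at all; its result is the limit noted at the limit of > 20000 nM in this assay, at which 1 of the 3 values shown sits, reached by an at least 150-fold higher number from compound 1 to compound 3 (2.18 log units; beyond the scatter).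

Compound 4 `COc1ncnc2c1c(-c1ccccc1)cn2[C@@H]1O[C@H](CO)[C@@H](O)[C@H]1O` differs from compound 1 by phenyl in place of thiophen-3-yl on an aromatic carbon. Neither measured step touches the group on that carbon: both a 15-fold higher number from compound 1 to compound 2 (1.17 log units; beyond the scatter) and an at least 150-fold higher number from compound 1 to compound 3 (2.18 log units; beyond the scatter) alter substituents on the other ring of the shared core, and both are large. For the measured compounds named here, no measured step therefore bears directly on the change to compound 4, and no direction can be read from the two that exist. The expectation is a step of modest size, toward a somewhat higher number, a 1.7-fold higher number from compound 1 to compound 4 (0.23 log units; within the scatter), with wide uncertainty. For compound 4 in this assay the estimate is 220 nM, ranging from 60 nM to 800 nM.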

Compound 4, half-maximal inhibitory concentration: > 20000 nM
Compound 4: a limit, no number (the forecaster's own chance of this, stated with the estimate: 5%); middle value at least 90-fold (1.95 log units) from the limit.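

In this assay compound 4 gives only a limit of the assay, > 20000 nM. For the compounds shown here, replacing thiophen-3-yl with phenyl on this aromatic carbon gives an at least 150-fold higher number from compound 1 to compound 4 (2.18 log units; beyond the scatter), so the position carrying the aryl ring is as sensitive to change as the substituents on the other ring of the shared core, which were the only places varied among compounds 1 to 3. With this result, compound 4 ends at the assay limit, as compound 3 does: the limit of > 20000 nM in this assay, at which 2 of the 4 values shown sit.

The change from thiophen-3-yl to phenyl alters both the ring size and the presence of sulfur, so the compounds shown do not separate these two differences. Furan-3-yl, thiophen-2-yl or a pyridine ring at this carbon would help show which ring features the read-out follows.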